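Tetrazole swapped for a carboxylic acid on compound 2

The compounds below may be only part of what the source reports. "The series", "measured", "known", "first", "only" and "open" are said of these compounds alone.

Measured compounds in a functional assay (lung) for inhibition, with Cavia porcellus as the target; on this read-out higher numbers stand for weaker inhibition and lower numbers for stronger inhibition:
compound 1 `CCCC(CCc1nnn[nH]1)Cc1cccc(OCc2ccc3ccccc3n2)c1`: 16 nM
compound 2 `c1cc(CCCCc2nnn[nH]2)cc(OCc2ccc3ccccc3n2)c1`: 105 nM
compound 3 `c1ccc(C(CCc2nnn[nH]2)Cc2cccc(OCc3ccc4ccccc4n3)c2)cc1`: 24 nM

Compound 2 gives the highest number of the three, so it is the weakest inhibitor in this set; the others sit below it, with compound 3 closest and compound 1 furthest away. Both measured steps leaving compound 2 replace the hydrogen on a saturated chain carbon bound to two saturated chain carbons: a 4.4-fold lower number from compound 2 to compound 3 (0.64 log units; beyond the scatter) and, read backwards, a 6.6-fold higher number from compound 1 to compound 2 (0.82 log units; beyond the scatter). They show that a group on that chain carbon lowers the number modestly.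

Compound 4 `CC(Cc1cccc(OCc2ccc3ccccc3n2)c1)CC(C)C(=O)O` is a different kind of change: 3-carboxy-1-methylbutyl in place of 3-(1H-tetrazol-5-yl)propyl on a saturated chain carbon bound to an aromatic carbon. The acidic tetrazole ring is exchanged for a carboxylic acid, and the chain is branched at a new place. Going by the values given here, no measured step touches either the tetrazole or this part of the chain, so the known steps give no direct guide. Acid-for-tetrazole swaps frequently keep a value in the same neighbourhood, so the expected step for compound 4 is a 1.4-fold higher number from compound 2 to compound 4 (0.15 log units; within the scatter), with wide uncertainty. Compound 4 is therefore estimated at 150 nM, within a range from 40 nM to 600 nM.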

Compound 4, half-maximal inhibitory concentration: 500 nM
For compound 4 the middle estimate is 3.3-fold (0.52 log units) below the measured one, and the stated range covers the measured number.
By their numbers in this assay, from the lowest: compounds 1 and 3 (each within the scatter of the next); then compound 2; then compound 4.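

Going by these compounds alone, compound 4 changes the chain that carries the tetrazole ring, and in this assay this gives a 4.8-fold higher number from compound 2 to compound 4 (0.68 log units; beyond the scatter) and is the only step leaving compound 2 that raises the number, which here means weaker inhibition. The earlier steps shown here from compound 2 changed only a chain carbon, kept the tetrazole ring and lowered the number, so this result adds a first case in which a change to the chain goes the other way. Putting 3-carboxy-1-methylbutyl in place of 3-(1H-tetrazol-5-yl)propyl, on a saturated chain carbon bound to an aromatic carbon, therefore does not keep the number of compound 2, and nothing available here explains why.

Compound 4 loses the tetrazole ring and gains new branching in one step, so the compounds shown do not tell how much of the rise belongs to each change. An unbranched chain ending in a carboxylic acid would separate the two, and a chain ending in a sulfonamide or a primary amide would show whether any other end group can stand in for the tetrazole ring.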